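From 3-methylphenyl to 4-hydroxyphenyl on a sulfonamide nitrogen

The compounds below may be only part of what the source reports. "The series", "measured", "known", "first", "only" and "open" are said of these compounds alone.

Compound 1 (`CCN(c1ccc(C)cc1)S(=O)(=O)C1CC2OC1C(c1ccc(NC(=O)CCCCCCC(=O)O)cc1)=C2c1ccc(O)cc1`) and compound 2 (`CCN(c1cccc(C)c1)S(=O)(=O)C1CC2OC1C(c1ccc(NC(=O)CCCCCCC(=O)O)cc1)=C2c1ccc(O)cc1`) differ only in the group on a sulfonamide nitrogen. In a functional assay on DU-145 cells (Homo sapiens) for antiproliferative activity, read by MTT assay, with a stated time of 72 h (a higher number here means a weaker inhibitor, a lower number a stronger inhibitor), compound 1 gives 53500 nM and compound 2 gives 65600 nM on the same read-out. Among the compounds with values here, these are the only two numbers so far, and they lie within the scatter of each other, so compound 2 stands level with compound 1. Compound 3 (`CCN(c1ccc(O)cc1)S(=O)(=O)C1CC2OC1C(c1ccc(NC(=O)CCCCCCC(=O)O)cc1)=C2c1ccc(O)cc1`) carries 4-hydroxyphenyl in place of 3-methylphenyl on a sulfonamide nitrogen. Within the data shown here, only one measured step bears on this change: a 1.2-fold higher number from compound 1 to compound 2 (0.09 log units; within the scatter) with 3-methylphenyl in place of 4-methylphenyl on a sulfonamide nitrogen. Among the measured compounds shown here, that step is small, but no measured compound carries 4-hydroxyphenyl at this place, so it is a weak guide. The expected step is therefore a 1.3-fold lower number from compound 2 to compound 3 (0.12 log units; within the scatter) and nothing beyond the scatter is expected in either direction. In this assay compound 3 is estimated at 50000 nM with a range from 20000 nM to 100000 nM as the expected span.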

Compound 3, half-maximal inhibitory concentration: > 100000 nM
Compound 3 ended at the assay's limit (the forecaster's own chance of this, stated with the estimate: 15%); middle value at least 2.0-fold (0.30 log units) from the limit.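

In this assay compound 3 gives > 100000 nM, which is a limit of the assay and not a number: the limit of > 100000 nM in this assay, at which 1 of the 3 values shown sits. This gives an at least 1.5-fold higher number from compound 2 to compound 3 (0.18 log units; that floor lies within the scatter) for the change to 4-hydroxyphenyl and an at least 1.8-fold higher number from compound 1 to compound 3 (0.27 log units; that floor lies within the scatter) for hydroxy in place of methyl on an aromatic carbon; both are floors, so the true gaps may be larger, but neither is yet shown to pass the scatter. Within the data shown here, still, moving the methyl gave only a 1.2-fold higher number from compound 1 to compound 2 (0.09 log units; within the scatter) with readable numbers on both sides, whereas 4-hydroxyphenyl, with its hydrogen-bond donor and acceptor, is the first group on this sulfonamide nitrogen to give no readable number, and it brings no lower number.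

From the compounds shown here alone, how far past the limit compound 3 lies stays unknown, so the true size of the hydroxy change cannot be fixed. Also open, going by these compounds, is whether a methoxy, an amine or a carboxylic acid in place of that hydroxy would return a readable number in this assay at all, which would show whether the loss of a readable number belongs to the hydroxy alone.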